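The source may hold more compounds than are shown below. What is called first, only, known or untested is meant among the compounds shown, and "the series" means these compounds.

Compound 1 `c1cc(N2CCCCC2)nc(Nc2ccc(Oc3ncnc4sccc34)cc2)n1`: 66.3%
Compound 2 `CN(c1ccc(Oc2ncnc3sccc23)cc1)c1nccc(N2CCCCC2)n1`: 52.2%
Compound 3 `c1ccc2c(c1)CCN(c1ccnc(Nc3ccc(Oc4ncnc5sccc45)cc3)n1)C2`: 18.1%

All three were tested in a functional assay on HCT-116 cells (Homo sapiens) for inhibition, read by MTT assay, with a stated time of 72 h, tested at 20 uM; a higher number here means more inhibition at the concentration tested (going by the name of the read-out), a lower number less inhibition. Compound 2 differs from compound 1 by methyl in place of hydrogen on a nitrogen on an aromatic ring, a change that produced the step of a number 14.1 percentage points lower from compound 1 to compound 2 (beyond the scatter). Compound 3 has a different core: against compound 1 it shows (1,2,3,4-tetrahydroisoquinolin-2-yl in place of piperidin-1-yl on an aromatic carbon), and that change produced the step of a number 48.2 percentage points lower from compound 1 to compound 3 (beyond the scatter), leaving compound 3 with the lowest number of the three.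

Compound 4 `CN(c1ccc(Oc2ncnc3sccc23)cc1)c1nccc(N2CCc3ccccc3C2)n1` is not yet measured. It differs from compound 3 by methyl in place of hydrogen on a nitrogen on an aromatic ring, at a place described in the same words as for compound 1 and compound 2, so it is the same change carried onto the other core. Compound 4 is expected to lose a little more, a number 11.1 percentage points lower from compound 3 to compound 4 (beyond the scatter), because the earlier step was a number 14.1 percentage points lower from compound 1 to compound 2 (beyond the scatter); with compound 3 already low in this assay, the number should sit near the bottom of the scale. Compound 4 is estimated at 7%, between -5% and 20%.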

Compound 4, a percentage reported as inhibition, at one concentration (the size of the read-out at that concentration, not a potency): 57.7%
Estimate against measurement, compound 4: 50.7 percentage points below, and the stated range ends below it.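

In this assay, putting methyl on the nitrogen did not have a single, transferable effect, giving a number 39.6 percentage points higher from compound 3 to compound 4 (beyond the scatter) while pointing the other way on the core of compound 1: the same change on two cores in this assay, a number 14.1 percentage points lower (beyond the scatter) from compound 1 to compound 2 and a number 39.6 percentage points higher (beyond the scatter) from compound 3 to compound 4, 53.7 percentage points apart, beyond the scatter of two such steps. The swap of piperidin-1-yl for 1,2,3,4-tetrahydroisoquinolin-2-yl also depended on the partner change, giving a number 5.5 percentage points higher from compound 2 to compound 4 (within the scatter) once the methyl was present: the same change on two cores in this assay, a number 48.2 percentage points lower (beyond the scatter) from compound 1 to compound 3 and a number 5.5 percentage points higher (within the scatter) from compound 2 to compound 4, 53.7 percentage points apart, beyond the scatter of two such steps. These four compounds show that the two changes do not simply add up here, but they do not show why, or whether this holds beyond these compounds.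

Still open, going by these compounds, is whether an ethyl group on that nitrogen, or morpholin-4-yl in place of piperidin-1-yl, would follow either pattern. A read-out at one concentration also leaves the potency of all four compounds open.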